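A few compounds are considered here, and "the series" means these few. Any claim that something is new, unique, unknown or untested is made for them only; others in the source may bear on it.

Compound 1, `C[C@H](Nc1ncnc2[nH]cnc12)c1nn(-c2cccnc2)c2cc(F)ccc12`, is the starting point of this account. In a functional assay on HepG2 cells (Homo sapiens) for inhibition, read by sulforhodamine B assay, with a stated time of 72 h, tested at 10 uM (a higher number here means more inhibition at the concentration tested (going by the name of the read-out), a lower number less inhibition), compound 1 gives 23%, and it stands level with compound 3, `C[C@H](Nc1ncnc2[nH]cnc12)c1nn(-c2cccc(S(C)(=O)=O)c2)c2cc(F)ccc12`, which gives 23% in this assay; together they are the lowest of the three numbers. Compound 2, `C[C@H](Nc1ncnc2[nH]cnc12)c1nn(-c2ccncc2)c2cc(F)ccc12`, gives 47% in this assay, and the step of a number 24 percentage points higher from compound 1 to compound 2 (beyond the scatter) is the largest among the measured ones, while no change at the digits printed from compound 1 to compound 3 (within the scatter) and a number 24 percentage points lower from compound 2 to compound 3 (beyond the scatter) complete the picture. All three of those steps exchange the group on the aromatic nitrogen. The step to compound 4, `C[C@H](Nc1nc(N)nc2[nH]cnc12)c1nn(-c2cccnc2)c2cc(F)ccc12`, is of a different kind: amino in place of hydrogen on an aromatic carbon. Among the compounds with values here, it alters the shared core, which no measured step touches, so none of them bears directly on it. With nothing to point either way, the step of a number 2 percentage points higher from compound 1 to compound 4 (within the scatter) is expected to stay within the scatter. Compound 4 is therefore estimated at 25% in this assay, within a range from 8% to 45%.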

Compound 4, a percentage reported as inhibition, at one concentration (the size of the read-out at that concentration, not a potency): 11%
For compound 4 the middle estimate is 14 percentage points above the measured one, and the stated range covers the measured number.
By their numbers in this assay, from the lowest: compound 4; then compounds 1 and 3 (each within the scatter of the next); then compound 2.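

In this assay, amino in place of hydrogen on an aromatic carbon, between two ring nitrogen atoms, gives a number 12 percentage points lower from compound 1 to compound 4 (beyond the scatter), which shows that this position of the shared core is not indifferent to substitution. Within the data shown here, the earlier steps all exchanged the group on the aromatic nitrogen, so this is the first reading on the core itself, taken with the pyridin-3-yl group held fixed. Nothing measured here gives a reason for this step.

From the compounds shown here alone, it remains open whether a methylamino group, a hydroxyl group or a chlorine atom at this position would behave as amino does. Going by these compounds, it is also open whether amino would bring a similar step when the aromatic nitrogen carries the pyridin-4-yl group of compound 2 instead.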